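The source may hold more compounds than are shown below. What is called first, only, known or untested is meant among the compounds shown, and "the series" means these compounds.

Compound 1 `COc1ccccc1CNC(=O)CSc1c[nH]c2cccc(Br)c12` is one of three compounds whose toxicity toward a human kidney cell line has been measured in an ADME assay on HEK-293T cells (Homo sapiens) for cytotoxicity, read by CCK-8 assay, with a stated time of 24 h; on this read-out higher numbers stand for lower toxicity in this test and lower numbers for higher toxicity in this test. In this assay compound 1 gives > 100000 nM, which is a limit of the assay rather than a number. Compound 3 `C[C@@H](NC(=O)CSc1c[nH]c2ccccc12)c1ccccc1` likewise gives > 100000 nM in this assay, again a limit. Compound 2 `CN(Cc1ccccc1)C(=O)CSc1c[nH]c2cccc(Br)c12` gives a numerical result of 25100 nM in this assay. Compound 1 therefore stands at the limit of > 100000 nM in this assay, at which 2 of the 3 values shown sit, and nothing more precise can be said of it.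

Compound 4 `O=C(CSc1c[nH]c2cccc(Br)c12)NCc1ccc(Cl)c(Cl)c1` has not yet been measured. It differs from compound 1 in one place: 3,4-dichlorophenyl in place of 2-methoxyphenyl on a saturated chain carbon bound to an amide-type nitrogen. Going by the values given here, no two measured compounds differ in a single place, so the size of such a change cannot be read from any measured step. The step of an at least 1.6-fold lower number from compound 1 to compound 4 (0.22 log units; that floor lies within the scatter) is expected to be small, leaning toward higher toxicity but not clearly beyond the usual scatter. Compound 4 is therefore estimated at 60000 nM, with a likely range between 20000 nM and 150000 nM.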

Compound 4, half-maximal cytotoxic concentration: > 100000 nM
Compound 4: only a limit was reported; the forecaster's own chance of this, stated with the estimate: 45%; middle value at least 1.6-fold (0.22 log units) from the limit.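

In this assay compound 4 gives > 100000 nM, which is a limit and not a number. Compound 1 also sits at a limit, so no step between compound 1 and compound 4 can be read: the limit of > 100000 nM in this assay, at which 3 of the 4 values shown sit.

Going by these compounds, whether 3,4-dichlorophenyl and 2-methoxyphenyl differ at all in toxicity in this test stays open.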